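Swapping the benzyl group on a piperazine side chain

The source may report more compounds than this note shows. Statements on the series, on what has been measured and on what is new or still open speak of the compounds shown alone.

Compound 1 `COC(=O)C1=CN(C(C)C)C(=O)[C@@H]2C(CN3CCN(Cc4ccc(C(F)(F)F)cc4)CC3)=CC[C@H]12`: 85.7%
Compound 2 `COC(=O)C1=CN(C)C(=O)[C@@H]2C(CN3CCN(Cc4ccc(C(F)(F)F)cc4)CC3)=CC[C@H]12`: 80.9%

Both were tested in a functional assay on Cortical neurone cells (Rattus norvegicus, strain Sprague-Dawley), read by MTT assay, with stated times of 24 h and 2 h, tested at 10 uM; on this read-out higher numbers stand for a stronger effect at the one concentration tested and lower numbers for a weaker effect. For the measured compounds named here, compound 1 gives 85.7% and compound 2 gives 80.9%; the only measured step, a number 4.8 percentage points lower from compound 1 to compound 2 (within the scatter), lies within the scatter, so the two stand level. Compound 3 `COC(=O)C1=CN(C(C)C)C(=O)[C@@H]2C(CN3CCN(Cc4cccc(OC)c4)CC3)=CC[C@H]12` has not yet been measured. It differs from compound 1 by 3-methoxyphenyl in place of 4-(trifluoromethyl)phenyl on a saturated chain carbon bound to an amine nitrogen in a ring. Going by the values given here, no measured step touches this part of the molecule, so the one known step gives no guidance on size or direction here. With nothing pointing either way, compound 3 is expected to give 78% (range 58% to 92%), and the step of a number 7.7 percentage points lower from compound 1 to compound 3 (within the scatter) is estimated to stay within the scatter.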

Compound 3, a percentage reported as activity, at one concentration (the size of the read-out at that concentration, not a potency): 64%
Compound 3: the middle estimate sits 14 percentage points above what was measured, within the range that was stated.
By their numbers in this assay, from the lowest: compound 3; then compounds 2 and 1 (each within the scatter of the next).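

Unlike the methyl-for-isopropyl step, this change on the benzyl group moves the read-out measurably: in this assay, 3-methoxyphenyl in place of 4-(trifluoromethyl)phenyl gives a number 21.7 percentage points lower from compound 1 to compound 3 (beyond the scatter). So the group at this place on the side chain affects the result at the one concentration tested. No available evidence explains the drop.

The swap changes both the substituent and its number on the ring, and these two compounds cannot separate those changes. From the compounds shown here alone, how a plain phenyl or a pyridine ring would behave here also remains open.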